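Opening a sulfonamide ring on a prostaglandin D2 receptor antagonist

The source may hold more compounds than are shown below. What is called first, only, known or untested is meant among the compounds shown, and "the series" means these compounds.

Measured compounds:
compound 1 `CC(C)c1ccc(S(C)(=O)=O)cc1C#Cc1cc(C#N)ccc1OCC(=O)O` gives 12 nM
compound 2 `Cc1ccc(S(=O)(=O)N2CCN(C)CC2)cc1C#Cc1cc(Cl)ccc1OCC(=O)O` gives 21 nM

The two measured compounds were tested in an assay on CHO cells for displacement of a labelled ligand from prostaglandin D2 receptor 2 (Homo sapiens), read by scintillation counting; on this read-out lower numbers stand for stronger inhibition and higher numbers for weaker inhibition. Compound 1 gives 12 nM, and compound 2 gives 21 nM. Compound 2 has the higher of the two numbers, but its nearest neighbour is compound 1, and the gap between them lies within the scatter of repeated measurements, so the two compounds are not separated by this assay.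

Compound 3 `Cc1ccc(S(=O)(=O)N(C)CCCN(C)C)cc1C#Cc1cc(Cl)ccc1OCC(=O)O` has not yet been measured. It differs from compound 2 in one place: (3-(dimethylamino)propyl)(methyl)amino in place of 4-methylpiperazin-1-yl on a sulfonyl sulfur. The basic nitrogen is kept, but the six-membered ring is replaced by an open chain carrying the same two nitrogen atoms. For the measured compounds named here, no step between measured compounds shows the effect of such a change, so nothing in the data forces a move in either direction. The expectation is for a step from compound 2 to compound 3 of a 1.2-fold higher number from compound 2 to compound 3 (0.08 log units; within the scatter), which is no step beyond the scatter. For compound 3 the estimated value in this assay is 25 nM, in a range from 8 nM to 80 nM.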

Compound 3, inhibition constant: 287 nM
Beside the measured number, compound 3's estimate is 11-fold (1.06 log units) below it; measured number above the stated range.
By their numbers in this assay, from the lowest: compounds 1 and 2 (each within the scatter of the next); then compound 3.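

In this assay, the sulfonyl sulfur proves sensitive to the group it carries: (3-(dimethylamino)propyl)(methyl)amino in place of 4-methylpiperazin-1-yl gives a 14-fold higher number from compound 2 to compound 3 (1.14 log units; beyond the scatter), a large step beyond the scatter. The two groups have the same counts of nitrogen atoms, hydrogen-bond donors and hydrogen-bond acceptors, and neither carries a net charge, so matching these counts does not preserve the number seen for compound 2; what differs in the count is the six-membered ring, which is lost, and the heavy-atom total. Nothing in the data shows which feature of this change accounts for the step.

The compounds shown leave open whether the loss follows from opening the ring or from the length of the chain, a question that a (2-(dimethylamino)ethyl)(methyl)amino group or a ring such as morpholin-4-yl or 4-methylpiperidin-1-yl on the same sulfonyl sulfur could address. They also leave open whether a step of this size would recur on another core, since this change is seen only once, on the core of compound 2.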